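Adding Vinylcarbonyl to an Antiproliferative Compound

This account rests on a few compounds, and the source may have more. Where it says the series, first, only, none or still open, it means among the compounds named here.

Compound 1 `O=C1/C(=C/c2ccc3ccccc3c2)CNC/C1=C\c1ccc2ccccc2c1`: 25200 nM in a functional assay on SF-268 cells (Homo sapiens) for antiproliferative activity, read by sulforhodamine B assay, with a stated time of 48 h; a lower number here means a stronger inhibitor of growth, a higher number a weaker inhibitor of growth
Compound 2 `Cc1ccc(/C=C2\CNC/C(=C\c3ccc(C)s3)C2=O)s1`: > 100000 nM in this assay, a limit of the assay

For the measured compounds named here, compound 1 holds the only exact number in this small set: in this assay, compound 1 gives 25200 nM. Compound 2 gives > 100000 nM, and this value is a limit and not a number.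

The next compound, compound 3 `C=CC(=O)N1C/C(=C\c2ccc3ccccc3c2)C(=O)/C(=C/c2ccc3ccccc3c2)C1`, keeps the core of compound 1 and changes it in one place: vinylcarbonyl in place of hydrogen on an amine nitrogen in a ring. Put simply, vinylcarbonyl stands in place of hydrogen on an amine nitrogen in a ring.

Going by the values given here, no two measured compounds differ in just one place, so the data contain no direct measure of what this change does. The expectation is therefore a cautious judgement: a moderate move toward stronger growth inhibition in this assay, beyond the usual scatter but with no change still possible. The expected size of the move is a 4.2-fold lower number from compound 1 to compound 3 (0.62 log units; beyond the scatter). The estimated value for compound 3 is 6000 nM, with an expected range from 1500 nM to 30000 nM.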

Compound 3, concentration for total growth inhibition: 1100 nM
For compound 3 the middle estimate is 5.5-fold (0.74 log units) above the measured one; the measured number lies below the stated range.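

Placing vinylcarbonyl in place of hydrogen on an amine nitrogen in a ring gives a 23-fold lower number from compound 1 to compound 3 (1.36 log units; beyond the scatter) in this assay. For the compounds shown here, this is the first direct reading of this position, and it shows that growth inhibition responds strongly to what sits on this nitrogen, since compound 1 and compound 2 both carry only hydrogen there and so could say nothing about it. Nothing shown here reveals the reason for this gain in potency, as no measured property of the compounds bears on this step.

Going by these compounds alone, only one group on this nitrogen can be compared with hydrogen, so it remains open whether an acetyl group, which keeps the carbonyl but lacks the carbon-carbon double bond of vinylcarbonyl, or a plain methyl group would give a step of similar size. From the compounds shown here alone, compound 2 gives > 100000 nM, a limit of the assay and not a number, so it also remains open whether the same change would have a similar effect on compound 2.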